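The source may report more compounds than this note shows. Statements on the series, on what has been measured and on what is new or still open speak of the compounds shown alone.

Compound 3 `CCCCOC(=O)CNC(=O)[C@H](CSc1ccc([N+](=O)[O-])cc1[N+](=O)[O-])NC(=O)CC[C@H](NC(=O)COc1ccccc1)C(=O)OCCCC` stands at the ceiling of a toxicity assay on KB cells (Homo sapiens) for cytotoxicity, read by fluorescence, with a stated time of 3 days; on this read-out lower numbers stand for an effect already at smaller amounts and higher numbers for an effect only at larger amounts of compound. In this assay compound 3 gives > 300 uM, which is a limit of the assay and not a number. Compound 1 `CCCCOC(=O)CNC(=O)[C@H](CSc1ccc([N+](=O)[O-])cc1[N+](=O)[O-])NC(=O)CC[C@H](NC(=O)CCc1ccccc1)C(=O)OCCCC` sits at the same limit, giving > 300 uM in this assay. Compound 2 `CCCCOC(=O)CNC(=O)[C@H](CSc1ccc([N+](=O)[O-])cc1[N+](=O)[O-])NC(=O)CC[C@H](NC(=O)CCC(C)C)C(=O)OCCCC` is the only one of the three with a read number, giving 84 uM in this assay. Both measured steps that reach a number touch this limit: an at least 3.5-fold lower number from compound 1 to compound 2 (0.55 log units; beyond the scatter), and an at least 3.5-fold higher number from compound 2 to compound 3 (0.55 log units; beyond the scatter). The step that the two limits leave unreadable from compound 1 to compound 3 cannot be read because both values sit at the limit of > 300 uM in this assay, at which 2 of the 3 values shown sit.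

Compound 4 `CCCCOC(=O)CNC(=O)[C@H](CSc1ccc([N+](=O)[O-])cc1[N+](=O)[O-])NC(=O)CC[C@H](Nc1nc(N)nc(Cl)n1)C(=O)OCCCC` differs from compound 3 in one place: 4-amino-6-chloro-1,3,5-triazin-2-yl in place of (phenoxymethyl)carbonyl on an amine nitrogen. Among the compounds with values here, none of the measured steps carries the entering group, so they tell only that exchanging the group on this amine nitrogen can move the number at least modestly in either direction. With two of three values at the limit, compound 4 is expected to land near the limit or just under it, so the step of an at least 1.2-fold lower number from compound 3 to compound 4 (0.07 log units; that floor lies within the scatter) is estimated as small. The value of compound 4 in this assay is estimated at 250 uM, with a range from 70 uM to 1000 uM.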

Compound 4, concentration for half-maximal effect: > 300 uM
Compound 4: a limit, no number; the forecaster's own chance of this, stated with the estimate: 60%; at least 1.2-fold (0.07 log units) between middle value and limit.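

In this assay compound 4 gives > 300 uM, which is a limit of the assay and not a number. Exchanging the acyl groups on this amine nitrogen for 4-amino-6-chloro-1,3,5-triazin-2-yl, an aromatic ring with hetero atoms, brings a group of a new kind to this position, and it gives an at least 3.5-fold higher number from compound 2 to compound 4 (0.55 log units; beyond the scatter), so compound 2, with isopentylcarbonyl, remains the only one of the four with a read number and the one exception to an otherwise uniform result at the limit. The steps from compound 1 and from compound 3 to compound 4 cannot be read, because both values of each pair stand at the same limit: the limit of > 300 uM in this assay, at which 3 of the 4 values shown sit.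

The compounds shown leave open whether the read number is tied to the branched chain of isopentylcarbonyl or would also appear with a saturated ring such as cyclohexylcarbonyl or with an unbranched hexanoyl group on this nitrogen. They also leave open how far compound 1, compound 3 and compound 4 differ beyond the limit, and whether a 4,6-diamino-1,3,5-triazin-2-yl group, with an amine in place of the chlorine, would bring the value back to a readable number.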